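Compound 2 to compound 3: a step from a limit

The source may report more compounds than this note shows. Statements on the series, on what has been measured and on what is new or still open speak of the compounds shown alone.

Measured in an ADME assay on KB cells (Homo sapiens) for cytotoxicity, with a stated time of 48 h; on this read-out lower numbers stand for stronger inhibition and higher numbers for weaker inhibition:
- Compound 1 `CC1=CCC[C@](C)(CC/C(C)=C/CC2=C(O)C(=O)C=C(N[C@@H](C(=O)O)[C@@H](C)O)C2=O)[C@@H]1C`: > 10 ug/mL, a limit
- Compound 2 `CC1=CCC[C@](C)(CC/C(C)=C/CC2=C(O)C(=O)C=C(N[C@H](CO)C(=O)O)C2=O)[C@@H]1C`: > 10 ug/mL, a limit

Compound 2 stands only at a limit, > 10 ug/mL. Compound 3 `CC1=CCC[C@](C)(CC/C(C)=C/CC2=C(O)C(=O)C=C(N[C@H](C(=O)O)[C@H](C)O)C2=O)[C@@H]1C` carries 1-carboxy-2-hydroxypropyl in place of 1-carboxy-2-hydroxyethyl on an amine nitrogen. Within the data shown here, the one measured step bearing on this change is a step that the two limits leave unreadable from compound 1 to compound 2, and its size cannot be read. All the evidence is the limit of > 10 ug/mL in this assay, at which 2 of the 2 values shown sit. The estimated step, a step that the limit leaves unreadable from compound 2 to compound 3, is expected to stay within the scatter in this assay, with no direction favoured. Compound 3 is expected at 15 ug/mL, within an estimated range of 7 ug/mL to 40 ug/mL.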

Compound 3, half-maximal inhibitory concentration: > 10 ug/mL
Compound 3: a limit, no number; the forecaster's own chance of this, stated with the estimate: 80%; the middle value is on the limit's open side.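

Compound 3 gives only a limit, as do compound 1 and compound 2, so no step among these three can be read. Still open, going by these compounds, is whether 1-carboxy-2-hydroxypropyl, or its drawn configuration, changes the read-out at all.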